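The compounds below may be only part of what the source reports. "The series", "measured", "known", "first", "only" and "open" are said of these compounds alone.

Compound 1 `CCOC(=O)C1=C(C)N(C)C(=O)NC1c1cccs1` and compound 2 `CCCOC(=O)C1=C(C)N(C)C(=O)NC1c1cccs1` share one core, while compound 3 `CCCC(=O)C1=C(C)NC(=O)NC1c1cccs1` rests on a core of its own; the difference between the two cores is not broken down here. In an assay on membranes from CHO cells for displacement of a labelled ligand from adenosine receptor A1 (Homo sapiens), read by scintillation counting, with a stated time of 60 min, tested at 1 uM (a lower number here means less inhibition, a higher number more inhibition at the concentration tested (going by the name of the read-out)), compound 1 gives 1%, compound 2 gives 9% and compound 3 gives 2%. Compound 2 arises from compound 1 by methyl in place of hydrogen on a saturated chain carbon, two bonds along the chain from an oxygen next to a carbonyl group, and that change produced a number 8 percentage points higher from compound 1 to compound 2 (within the scatter), so all three numbers sit close together at the low end of the read-out.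

Compound 4 `CC1=C(C(=O)CC(C)C)C(c2cccs2)NC(=O)N1` has not yet been tested in this assay. It arises from compound 3 by methyl in place of hydrogen on a saturated chain carbon bound to two saturated chain carbons. Among the measured compounds shown here, this is the same kind of change as the one from compound 1 to compound 2, but the place differs: earlier the saturated chain carbon was two bonds along the chain from an oxygen next to a carbonyl group, whereas here it is bound to two saturated chain carbons. Because a number 8 percentage points higher from compound 1 to compound 2 (within the scatter) held within the scatter, a step of similar size is expected, namely a number 2 percentage points higher from compound 3 to compound 4 (within the scatter). On that basis compound 4 is expected to give about 4% in this assay, with a likely range from -5% to 15%.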

Compound 4, a percentage reported as inhibition, at one concentration (the size of the read-out at that concentration, not a potency): 19%
Beside the measured number, compound 4's estimate is 15 percentage points below it; measured number above the stated range.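

In this assay the methyl change gives a number 17 percentage points higher from compound 3 to compound 4 (beyond the scatter) on the second core, and this step cannot be told apart from the earlier one on the first core: the same change on two cores in this assay, a number 8 percentage points higher (within the scatter) from compound 1 to compound 2 and a number 17 percentage points higher (beyond the scatter) from compound 3 to compound 4, 9 percentage points apart, within the scatter of two such steps. So the two results are compatible with the change carrying over from one core to the other, even though only the newer step stands clear of the scatter. Among the compounds shown here, this does not prove that the change acts alike on both cores, as there is only one pair per core, the methyl sits at a different place in each pair, and each number comes from a single concentration, which gives no potency.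

The compounds shown leave open what a longer chain such as pentyl, or a chain ending in an amine or a carboxylic acid, would give in place of the isobutylcarbonyl chain of compound 4. Also open, going by these compounds, is whether the same methyl change would give a similar step on any further core.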